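From fluorophenyl to imidazolyl in a cytotoxicity series

The source may report more compounds than this note shows. Statements on the series, on what has been measured and on what is new or still open speak of the compounds shown alone.

Compound 1 `Cc1ccc(CN2CCC(C(=O)Nc3ccc(CNc4nc(N(C)C)nc5cc(C)ccc45)cc3)CC2)cc1`: > 4150 nM
Compound 2 `Cc1ccc2c(NCc3ccc(NC(=O)C4CCN(Cc5cccc(F)c5)CC4)cc3)nc(N(C)C)nc2c1`: > 4170 nM

In a functional assay on SV5A8 cells (Homo sapiens) for cytotoxicity (on this read-out higher numbers stand for weaker inhibition and lower numbers for stronger inhibition), compound 1 gives > 4150 nM, which is a limit of the assay rather than a number. Compound 2 in this assay gives > 4170 nM, also a limit. For the measured compounds named here, the one measured step, a step that the two limits leave unreadable from compound 1 to compound 2, therefore cannot be read; compound 2 stands at a limit, and the only other value, at the limit of > 4150 nM in this assay, at which 1 of the 2 values shown sits, is a limit too, so compound 2 sits at the limit of > 4170 nM in this assay, at which 1 of the 2 values shown sits, with no ordering possible.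

Compound 3 `Cc1ccc2c(NCc3ccc(NC(=O)C4CCN(Cc5ncc[nH]5)CC4)cc3)nc(N(C)C)nc2c1` has not been measured. It differs from compound 2 by 1H-imidazol-2-yl in place of 3-fluorophenyl on a saturated chain carbon bound to an amine nitrogen in a ring. No readable step bears on this change, and both neighbours stop at limits. Compound 3 is therefore expected to stay near the limit as well, with an estimate of 6000 nM spanning 1500 nM to 30000 nM. The expected step from compound 2 is a step that the limit leaves unreadable from compound 2 to compound 3.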

Compound 3, half-maximal inhibitory concentration: > 20000 nM
Compound 3 gave a limit, no number (the forecaster's own chance of this, stated with the estimate: 75%); at least 3.3-fold (0.52 log units) between middle value and limit.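

For the compounds shown here, compound 1, compound 2 and compound 3 all stop at limits in this assay, not at numbers, so no step among them can be read. The compounds shown leave open whether 1H-imidazol-2-yl in place of 3-fluorophenyl changes the read-out at all.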